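The source may hold more compounds than are shown below. What is called first, only, known or untested is meant among the compounds shown, and "the series" means these compounds.

Measured in a functional assay on A-431 cells (Homo sapiens) for cytotoxicity, read by MTT assay, with a stated time of 24 h; on this read-out higher numbers stand for weaker inhibition and lower numbers for stronger inhibition:
Compound 1 `COc1ccc(/C=C\C(=O)O)c(OCc2cn(-c3ccccc3)nn2)c1CC=C(C)C` gives 21200 nM.
Compound 2 `COc1ccc(/C=C\C(=O)O)c(OCc2cn(-c3cccc([N+](=O)[O-])c3)nn2)c1CC=C(C)C` gives 18400 nM.
Compound 3 `COc1ccc(/C=C\C(=O)O)c(OCc2cn(-c3cccc(C#N)c3)nn2)c1CC=C(C)C` gives 22900 nM.

These three numbers sit together: the steps of a 1.1-fold higher number from compound 1 to compound 3 (0.03 log units; within the scatter) and a 1.2-fold higher number from compound 2 to compound 3 (0.10 log units; within the scatter) are both within the scatter, so compound 3 is not set apart from the others. Compound 4 `COc1ccc(/C=C\C(=O)O)c(OCc2cn(-c3cccnc3Cl)nn2)c1CC=C(C)C` is the next compound, and its change is 2-chloropyridin-3-yl in place of 3-cyanophenyl on an aromatic nitrogen. The measured steps, a 1.2-fold lower number from compound 1 to compound 2 (0.06 log units; within the scatter), a 1.1-fold higher number from compound 1 to compound 3 (0.03 log units; within the scatter) and a 1.2-fold higher number from compound 2 to compound 3 (0.10 log units; within the scatter), each swap one small group on the aromatic ring and each stay within the scatter; none exchanges the ring itself, so they bear only loosely here. Compound 4 is therefore expected to give 21000 nM, between 10000 nM and 45000 nM, with a 1.1-fold lower number from compound 3 to compound 4 (0.04 log units; within the scatter) as the expected step.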

Compound 4, half-maximal inhibitory concentration: 32600 nM
The estimate for compound 4 lay 1.6-fold (0.19 log units) below the measured number; the measured number falls inside the stated range.
By their numbers in this assay, from the lowest: compounds 2, 1, 3 and 4 (each within the scatter of the next).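

Exchanging the whole ring on this aromatic nitrogen, not just one small group on it, still leaves the number in this assay within the scatter of every earlier compound (a 1.4-fold higher number from compound 3 to compound 4 (0.15 log units; within the scatter)) and (a 1.8-fold higher number from compound 2 to compound 4 (0.25 log units; within the scatter)) and (a 1.5-fold higher number from compound 1 to compound 4 (0.19 log units; within the scatter)). So at this position, a 2-chloropyridin-3-yl ring cannot be told apart from the carbon-only rings. Nothing measured here offers an explanation for this. The compounds shown do not separate the part played by the ring nitrogen from that of the chlorine. From the compounds shown here alone, whether an amine on this ring, or a longer chain in its place, would move the number beyond the scatter also remains open.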